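Urea terminus of the pyrrolidine amide series: ethyl to tert-butyl

The source may report more compounds than this note shows. Statements on the series, on what has been measured and on what is new or still open speak of the compounds shown alone.

Measured so far:
- compound 1 `CC(C)C(=O)N1CCC[C@H]1C(=O)N1CCC(NS(=O)(=O)c2cc(S(=O)(=O)c3ccccc3)ccc2C(F)(F)F)CC1` gives 90 nM
- compound 2 `CN(C)CC(=O)N1CCC[C@H]1C(=O)N1CCC(NS(=O)(=O)c2cc(S(=O)(=O)c3ccccc3)ccc2C(F)(F)F)CC1` gives 310 nM
- compound 3 `CCNC(=O)N1CCC[C@H]1C(=O)N1CCC(NS(=O)(=O)c2cc(S(=O)(=O)c3ccccc3)ccc2C(F)(F)F)CC1` gives 90 nM

All three share the core of compound 1 and differ only in the group on the pyrrolidine acyl carbon. Among the measured compounds shown here, in a functional assay on U2OS cells for antagonist activity at proto-oncogene Wnt-3 (Homo sapiens), read by a luciferase reporter, with a stated time of 18 h (on this read-out higher numbers stand for an effect only at larger amounts of compound and lower numbers for an effect already at smaller amounts), compound 3 stands level with compound 1 at the digits reported, the two of them together at the lowest numbers of the three; the only compound clearly apart is compound 2, as the step of a 3.4-fold lower number from compound 2 to compound 3 (0.54 log units; beyond the scatter) shows. The step of no change at the digits printed from compound 1 to compound 3 (within the scatter) shows that swapping the isopropyl amide for an ethyl urea leaves the read-out where it was, while a 3.4-fold higher number from compound 1 to compound 2 (0.54 log units; beyond the scatter) is the one modest movement in the set.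

Compound 4 `CC(C)(C)NC(=O)N1CCC[C@H]1C(=O)N1CCC(NS(=O)(=O)c2cc(S(=O)(=O)c3ccccc3)ccc2C(F)(F)F)CC1` carries the change (tert-butyl in place of ethyl on an amide-type nitrogen). For the measured compounds named here, no measured step touches the alkyl group on the urea nitrogen directly; the nearest point of comparison is that compound 1, bearing a branched isopropyl, and compound 3, bearing a straight ethyl, read the same in this assay. On that basis a step of no more than the scatter is expected, a 1.2-fold higher number from compound 3 to compound 4 (0.09 log units; within the scatter). Compound 4 is therefore estimated at 110 nM, within a range of 40 nM to 300 nM.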

Compound 4, half-maximal effective concentration: 30 nM
For compound 4 the middle estimate is 3.7-fold (0.56 log units) above the measured one; measured number outside the range, below it.
By their numbers in this assay, from the lowest: compound 4; then compounds 1 and 3 (each within the scatter of the next); then compound 2.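

In this assay, among the compounds shown here, the alkyl group on the amide-type nitrogen is not silent: tert-butyl in place of ethyl gives a 3.0-fold lower number from compound 3 to compound 4 (0.48 log units; beyond the scatter) and is the first change at this position to lower the number beyond the scatter. The isopropyl comparison is no longer flat either, with a 3.0-fold lower number from compound 1 to compound 4 (0.48 log units; beyond the scatter) where compound 3 had stayed level with compound 1, and the spread of the set widens to a large step with a 10-fold lower number from compound 2 to compound 4 (1.01 log units; beyond the scatter) as its extreme. Nothing at hand explains the difference between the ethyl and tert-butyl ureas.

Only ethyl and tert-butyl are compared on this nitrogen, so the shape of the trend is open. An isopropyl, a cyclohexyl or a phenyl on the same nitrogen would show whether the lower number belongs to tert-butyl alone.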